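The compounds below may be only part of what the source reports. "The series", "measured", "known", "first", "only" and "open" are said of these compounds alone.

Compound 1, `c1ccc(C(c2cccnc2)N2CCN(c3ncnc4c3cnn4-c3ccccc3)CC2)cc1`, in a functional assay on cells (Rhabdomyosarcoma cell, Homo sapiens) for cytotoxicity (a higher number here means a weaker inhibitor, a lower number a stronger inhibitor), gives > 25000 nM, which is a limit of the assay and not a number.
Compound 2, `c1ccc(-c2ccc(C(c3ccccc3)N3CCN(c4ncnc5c4cnn5-c4ccccc4)CC3)cc2)cc1`, in this assay gives > 25000 nM, again a limit of the assay.
Compound 3, `N#Cc1ccc(C(c2ccccc2)N2CCN(c3ncnc4c3cnn4-c3ccccc3)CC2)cc1`, in this assay gives > 25000 nM, again a limit of the assay.

Compound 1 therefore stands at the same limit as the other two measured compounds, all three sitting at the limit of > 25000 nM in this assay, at which 3 of the 3 values shown sit. None of the steps among them can be read: the step from compound 1 to compound 2 is a step that the two limits leave unreadable from compound 1 to compound 2, the step from compound 1 to compound 3 is a step that the two limits leave unreadable from compound 1 to compound 3, and the step from compound 2 to compound 3 is a step that the two limits leave unreadable from compound 2 to compound 3.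

The unmeasured compound 4, `c1ccc(C(c2ccccn2)N2CCN(c3ncnc4c3cnn4-c3ccccc3)CC2)cc1`, differs from compound 1 in one place: pyridin-2-yl in place of pyridin-3-yl on a saturated chain carbon bound to an amine nitrogen in a ring and an aromatic carbon. The measured steps that bear on this position, the ones from compound 1 to compound 2 and from compound 1 to compound 3, are both unreadable, so they give no direction and no size. Since every measured analogue sits at the limit, the expectation for compound 4 is that it too will most likely sit at the limit, with an expected step that the limit leaves unreadable from compound 1 to compound 4 that is not distinguishable from none. Compound 4 is therefore estimated at 50000 nM, with a range of 20000 nM to 200000 nM.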

Compound 4, half-maximal inhibitory concentration: > 25000 nM
Compound 4: a limit, no number (the forecaster's own chance of this, stated with the estimate: 85%); the middle value does not contradict the limit.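

In this assay compound 4 gives > 25000 nM, a limit of the assay and not a number. Its steps to compound 1, compound 2 and compound 3 therefore cannot be read: the limit of > 25000 nM in this assay, at which 4 of the 4 values shown sit.

The compounds shown leave open whether any group on this saturated chain carbon changes the cytotoxicity at all, and by how much.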